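This account rests on a few compounds, and the source may have more. Where it says the series, first, only, none or still open, it means among the compounds named here.

Notes on the series in an assay on isolated protein for inhibition of Amine oxidase [flavin-containing] A (Rattus norvegicus); a higher number here means a weaker inhibitor, a lower number a stronger inhibitor. Compound 1 `CCNCc1cn(Cc2ccccc2)c2ccccc12` gives 263000 nM. Compound 2 `C#CCN(C)Cc1cc2ccccc2n1C` gives 0.302 nM, and compound 3 `CC#CCN(C)Cc1cc2ccccc2n1C` gives 4.27 nM; the difference between the core of compound 1 and the core of compound 2 is not broken down here. From compound 2 to compound 3 the change is methyl in place of hydrogen on a triple-bonded carbon, and it made a step of a 14-fold higher number from compound 2 to compound 3 (1.15 log units; beyond the scatter). Compound 4 `CC(C)NCc1cn(Cc2ccccc2)c2ccccc12` is not yet measured; its difference from compound 1 is methyl in place of hydrogen on a saturated chain carbon bound to an amine nitrogen and a saturated chain carbon. The two changes are the same kind of change, a methyl entering for hydrogen, but the place differs: on a triple-bonded carbon in one, on a saturated chain carbon bound to an amine nitrogen and a saturated chain carbon in the other. An added methyl is expected to weaken compound 4 modestly because of a 14-fold higher number from compound 2 to compound 3 (1.15 log units; beyond the scatter), though the place is not the same, so the estimate is loose. For compound 4 the expected value is 450000 nM, within 100000 nM to 2000000 nM. This estimate corresponds to an expected step of a 1.7-fold higher number from compound 1 to compound 4 (0.23 log units; within the scatter).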

Compound 4, inhibition constant: 132000 nM
Estimate against measurement, compound 4: 3.4-fold (0.53 log units) above; the range from low to high includes it.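

In this assay, methyl in place of hydrogen does not carry from one core to the other as a fixed step: the same change on two cores in this assay, a 14-fold higher number (1.15 log units; beyond the scatter) from compound 2 to compound 3 and a 2.0-fold lower number (0.30 log units; within the scatter) from compound 1 to compound 4, 28-fold (1.45 log units) apart, beyond the scatter of two such steps. On the core of compound 1 the change gives a 2.0-fold lower number from compound 1 to compound 4 (0.30 log units; within the scatter), so compound 4 cannot be told apart from compound 1 in this assay. The two methyl groups differ in place as well as in core, so these two steps cannot separate the part played by the core from the part played by the place, and they give no rule for other cores.

Still open, going by these compounds, is how a tert-butyl group or a longer chain in place of the ethyl of compound 1 would read in this assay. Also open, on these data alone, is whether any such group would leave the value within the scatter of compound 1 and compound 4.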